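This account rests on a few compounds, and the source may have more. Where it says the series, first, only, none or still open, it means among the compounds named here.

Compound 1 `Oc1cccc(-c2cc(-c3ccccc3C(F)(F)F)cc(-c3ccccc3O)n2)c1` gives 16800 nM in a functional assay on HeLa cells (Homo sapiens) for inhibition; on this read-out lower numbers stand for stronger inhibition and higher numbers for weaker inhibition.
Compound 2 `Oc1cccc(-c2cc(-c3ccccc3C(F)(F)F)cc(-c3cccc(O)c3)n2)c1` gives 15200 nM in this assay.
Compound 3 `Oc1ccccc1-c1cc(-c2ccc(OC(F)(F)F)cc2)cc(-c2ccccc2O)n1` is reported in this assay only as a limit, > 50000 nM, not as a number.

From compound 1 to compound 2 the change is 3-hydroxyphenyl in place of 2-hydroxyphenyl on an aromatic carbon, and it brings a 1.1-fold lower number from compound 1 to compound 2 (0.04 log units; within the scatter). Compound 4 `Oc1cccc(-c2cc(-c3ccc(OC(F)(F)F)cc3)cc(-c3ccccc3O)n2)c1`, not yet measured, carries the same kind of change with respect to compound 3, namely (3-hydroxyphenyl in place of 2-hydroxyphenyl on an aromatic carbon). The surroundings differ: in compound 3 the place is meta to a 2-hydroxyphenyl group and meta to a large group, whereas in compound 1 it is meta to a 2-(trifluoromethyl)phenyl group and meta to a 3-hydroxyphenyl group. How the core of compound 1 and the core of compound 3 differ is not broken down here. Compound 3 sits at the limit of > 50000 nM in this assay, at which 1 of the 3 values shown sits. Given a 1.1-fold lower number from compound 1 to compound 2 (0.04 log units; within the scatter), compound 4 is expected to stay near that limit. Compound 4 is estimated at 60000 nM, between 25000 nM and 150000 nM. The step thus expected is a step that the limit leaves unreadable from compound 3 to compound 4, and it may well be hidden by the limit.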

Compound 4, half-maximal inhibitory concentration: 20600 nM
The estimate for compound 4 lay 2.9-fold (0.46 log units) above the measured number, and the stated range ends above it.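

On the core of compound 3, 3-hydroxyphenyl in place of 2-hydroxyphenyl brings an at least 2.4-fold lower number from compound 3 to compound 4 (0.38 log units; beyond the scatter) in this assay. Compound 3 is known only as a limit, > 50000 nM, so the full size of this step cannot be read. Set beside the earlier step, this shows that the change is tolerated on both cores, but not that it carries from one core to the other with the same size: the same change on two cores in this assay, a 1.1-fold lower number (0.04 log units; within the scatter) from compound 1 to compound 2 and an at least 2.4-fold lower number (0.38 log units; beyond the scatter) from compound 3 to compound 4; the limit leaves it open whether they differ

The compounds shown leave open what 3-hydroxyphenyl in place of the remaining 2-hydroxyphenyl group of compound 4 would give. They also leave open whether an amine or a carboxylic acid could stand in place of the hydroxyl on either core.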